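The compounds below may be only part of what the source reports. "The series", "measured", "known", "first", "only" and "open" are said of these compounds alone.

Compound 1 `CCc1cc(C(C)=O)c(O)cc1OCCCCC#N` gives 57% in an assay on isolated protein for binding affinity to leukotriene B4 receptor 1 (Homo sapiens), tested at 1 uM; a higher number here means more inhibition at the concentration tested (going by the name of the read-out), a lower number less inhibition. Compound 2 `CC(=O)c1cc(CC(C)O)c(OCCCCC#N)cc1O` gives 6% in this assay.

Compound 2 stands lowest of the two measured numbers; its nearest neighbour is compound 1, and the step between them is a number 51 percentage points lower from compound 1 to compound 2 (beyond the scatter). Compound 3 `CC(=O)c1cc(C=O)c(OCCCCC#N)cc1O` differs from compound 2 by formyl in place of 2-hydroxypropyl on an aromatic carbon. That single large step is the only measured one that bears on the change, and it shows a chain bearing a hydroxy group pulling the number down. Compound 3 is therefore expected to recover part of that loss, by a number 24 percentage points higher from compound 2 to compound 3 (beyond the scatter). Compound 3 is estimated at 30%, between 5% and 60%.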

Compound 3, a percentage reported as inhibition, at one concentration (the size of the read-out at that concentration, not a potency): 3%
For compound 3 the middle estimate is 27 percentage points above the measured one; measured number below the stated range.
By their numbers in this assay, from the lowest: compounds 3 and 2 (each within the scatter of the next); then compound 1.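

Replacing 2-hydroxypropyl with formyl on this aromatic carbon recovers nothing in this assay: the change is a number 3 percentage points lower from compound 2 to compound 3 (within the scatter), so the shorter group carrying oxygen sits level with the hydroxy-bearing chain. Ethyl alone keeps the higher number here, and the change to formyl is a number 54 percentage points lower from compound 1 to compound 3 (beyond the scatter), a loss as large as that seen with 2-hydroxypropyl. No measurement explains why these two oxygen-bearing groups give such low numbers.

Going by these compounds, whether a propyl chain or a methyl group would hold the number of compound 1 remains open, as does whether a methoxy group or an amine on this carbon would lose it.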